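The source may report more compounds than this note shows. Statements on the series, on what has been measured and on what is new or still open speak of the compounds shown alone.

Of the compounds shown here, three of one shared core have been tested in a functional assay on HeLa cells (Homo sapiens) for antiproliferative activity, with a stated time of 24 h; a higher number here means a weaker inhibitor, a lower number a stronger inhibitor. Compound 1 `NC(=O)c1c(NC(=O)c2ccc(C(F)(F)F)cc2)sc2c1CCN(Cc1c(Cl)cccc1Cl)C2` carries a 4-(trifluoromethyl)phenyl group on the carbonyl carbon and a 2,6-dichlorophenyl group on a saturated chain carbon bound to an amine nitrogen in a ring. In this assay compound 1 reaches only the limit of > 50000 nM. Compound 2 `NC(=O)c1c(NC(=O)c2ccc(C(F)(F)F)cc2)sc2c1CCN(Cc1ccc(Cl)cc1Cl)C2` differs by a 2,4-dichlorophenyl in place of 2,6-dichlorophenyl at that chain carbon, and in this assay compound 2 also gives only the limit of > 50000 nM. The step from compound 1 to compound 2 is therefore a step that the two limits leave unreadable from compound 1 to compound 2. Among the measured compounds shown here, compound 3 `NC(=O)c1c(NC(=O)c2ccccc2Cl)sc2c1CCN(C(=O)Nc1ccccc1Cl)C2` gives the only actual number of the three, 45400 nM in this assay, and is thus the sole point from which anything can be measured.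

Compound 4 `NC(=O)c1c(NC(=O)c2ccc(C(F)(F)F)cc2)sc2c1CCN(C(=O)Nc1ccccc1Cl)C2` is still to be tested. Its change from compound 3 is 4-(trifluoromethyl)phenyl in place of 2-chlorophenyl on a carbonyl carbon. For the measured compounds named here, no measured step touches this carbonyl aryl group, so its size cannot be read from the data; the step from compound 1 to compound 2 concerns a different position and is anyway unreadable. Both compounds that carry the entering group sit at the limit of > 50000 nM in this assay, at which 2 of the 3 values shown sit. For compound 4 a value of 60000 nM is expected, within 20000 nM to 200000 nM, meaning an expected step of a 1.3-fold higher number from compound 3 to compound 4 (0.12 log units; within the scatter).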

Compound 4, half-maximal inhibitory concentration: > 50000 nM
Compound 4 ended at the assay's limit; the forecaster's own chance of this, stated with the estimate: 60%; the middle value is on the limit's open side.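

Placing 4-(trifluoromethyl)phenyl in place of 2-chlorophenyl on a carbonyl carbon gives an at least 1.1-fold higher number from compound 3 to compound 4 (0.04 log units; that floor lies within the scatter), the first step at this position with a real number at one end, although only its floor can be read and its true size stays open. Among the compounds shown here, until now the entering group had been seen only with a dichlorobenzyl group on the amine nitrogen in the ring, whereas with (2-chlorophenyl)carbamoyl there, compound 4 gives > 50000 nM in this assay, which is also a limit of the assay. The steps to compound 4 from compound 1 and compound 2 join two limits and cannot be read, and most of the set now rests at that same limit: the limit of > 50000 nM in this assay, at which 3 of the 4 values shown sit.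

The compounds shown leave open whether any other group on this carbonyl carbon, such as a pyridine ring, a chain ending in an amine or a benzene ring bearing a carboxylic acid, would give a clearly lower number in this assay. Also open, on these data alone, is how 2-chlorophenyl on the carbonyl carbon would read with a 2,4-dichlorobenzyl group on the amine nitrogen in the ring.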